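The source may hold more compounds than are shown below. What is called first, only, known or untested is meant among the compounds shown, and "the series" means these compounds.

In an assay on BaF3 cells for inhibition of Kinesin-1 heavy chain/ Tyrosine-protein kinase receptor RET (Homo sapiens), with a stated time of 48 h (a lower number here means a stronger inhibitor, a higher number a weaker inhibitor), compound 1 `COC(=O)NC12CCC(n3cc(-c4ccc(Cl)c(N)c4)c4c(N)ncnc43)(CC1)CC2` gives 20 nM and compound 2 `Nc1ncnc2c1c(-c1cccc(O)c1)cn2[C@H]1C[C@@H](CO)C1` gives 11 nM.

Compound 1 stands with compound 2 in this assay: the two numbers lie within the usual scatter of each other, so nothing separates them. Compound 3 `COC(=O)NC12CCC(n3cc(-c4cc(N)c(Cl)cc4F)c4c(N)ncnc43)(CC1)CC2` differs from compound 1 by fluoro in place of hydrogen on an aromatic carbon, in words fluoro in place of hydrogen on an aromatic carbon. Among the compounds with values here, no measured pair shows this change, so no size of step is known. A change of one heavy atom on this ring is expected to move the number little, if at all, in either direction beyond the scatter: the step from compound 1 to compound 3 is estimated at a 1.3-fold higher number from compound 1 to compound 3 (0.10 log units; within the scatter). Compound 3 is expected to give about 25 nM, between 8 nM and 80 nM.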

Compound 3, half-maximal inhibitory concentration: 22 nM
Compound 3: the middle estimate sits 1.1-fold (0.06 log units) above what was measured; the range from low to high includes it.
By their numbers in this assay, from the lowest: compounds 2, 1 and 3 (each within the scatter of the next).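

In this assay, fluoro in place of hydrogen on the aromatic carbon ortho to a large group and para to an amino group gives a 1.1-fold higher number from compound 1 to compound 3 (0.04 log units; within the scatter), so compound 1 and compound 3 cannot be told apart. Within the data shown here, this is the first measured reading at this position, and it shows that the position accepts a fluoro group with the number staying within the scatter. As far as these compounds go, whether methoxy or a carboxylic acid on this same carbon would leave the number equally undisturbed remains open. Nothing available explains why this fluoro step is so small.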